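Oxadiazolylmethyl on the anilino nitrogen of a cyanochromanol

A few compounds are considered here, and "the series" means these few. Any claim that something is new, unique, unknown or untested is made for them only; others in the source may bear on it.

Measured compounds:
compound 1, `CC1(C)Oc2ccc(C#N)cc2[C@H](Nc2ccccc2)[C@H]1O`: 1200 nM
compound 2, `CCOC(=O)CN(c1nc(C)cs1)[C@H]1c2cc(C#N)ccc2OC(C)(C)[C@@H]1O`: 84000 nM

Of the compounds shown here, two have been tested in a functional assay (aorta) with Rattus norvegicus as the target; a higher number here means a weaker inhibitor, a lower number a stronger inhibitor. Compound 1 has the lower of the two numbers; compound 2 gives 84000 nM, a much higher number than compound 1, and the gap between them lies well beyond the scatter. Among the measured compounds shown here, the two differ in several places at once, so their values show only that the pair sits far apart.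

Compound 3, `Cc1noc(CN(c2ccccc2)[C@H]2c3cc(C#N)ccc3OC(C)(C)[C@@H]2O)n1`, has not yet been measured. It differs from compound 1 as follows: (3-methyl-1,2,4-oxadiazol-5-yl)methyl in place of hydrogen on a nitrogen on an aromatic ring. Compound 1 gives 1200 nM in this assay. The step from compound 1 to compound 3 is expected to raise the number, most likely beyond the scatter, as a 5.0-fold higher number from compound 1 to compound 3 (0.70 log units; beyond the scatter). Compound 3 is therefore estimated at 6000 nM, with a range from 1500 nM to 30000 nM.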

Compound 3, half-maximal inhibitory concentration: > 30000 nM
Compound 3: a limit, no number; the forecaster's own chance of this, stated with the estimate: 5%; middle value at least 5.0-fold (0.69 log units) from the limit.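

In this assay, compound 3 reaches only a limit, > 30000 nM, and not a number. Among the compounds shown here, putting (3-methyl-1,2,4-oxadiazol-5-yl)methyl in place of hydrogen on the nitrogen on an aromatic ring gives an at least 25-fold higher number from compound 1 to compound 3 (1.39 log units; beyond the scatter), which is the first comparison that changes one place only. It shows that this nitrogen is sensitive to this change, and the size of the step is itself bounded by the limit: the limit of > 30000 nM in this assay, at which 1 of the 3 values shown sits.

On these data alone, whether the loss belongs to the oxadiazole ring or to any substituent on this nitrogen stays open, as does how far the step really reaches. A lone methyl group, or a short chain ending in an amine, at this place would help to separate these readings.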